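The source may report more compounds than this note shows. Statements on the series, on what has been measured and on what is new or still open speak of the compounds shown alone.

In a functional assay on SW-620 cells (Homo sapiens) for cytotoxicity, read by sulforhodamine B assay, with a stated time of 48 h (a lower number here means a stronger inhibitor, a higher number a weaker inhibitor), two compounds sharing one core have been measured. Compound 1 `COc1ccc(C2=NO[C@]3(C2)C(=O)O[C@@H]2[C@H]3CC[C@H](C)[C@]3(O)C=CC(=O)[C@@]23C)cc1OC`, which carries 3,4-dimethoxyphenyl, gives 86000 nM. Compound 2 `C[C@H]1CC[C@@H]2[C@@H](OC(=O)[C@]23CC(c2ccccc2F)=NO3)[C@]2(C)C(=O)C=C[C@@]12O`, which carries 2-fluorophenyl, gives 11000 nM, the lower of the two numbers and so the stronger result of this pair.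

Compound 3 `C[C@H]1CC[C@@H]2[C@@H](OC(=O)[C@]23CC(c2ccc(F)cc2)=NO3)[C@]2(C)C(=O)C=C[C@@]12O` keeps the core of compound 2 and has 4-fluorophenyl in place of 2-fluorophenyl on a carbon with a double bond to nitrogen. The two compounds have the same atoms, joined differently.

Among the compounds with values here, only one measured step bears on this change: a 7.8-fold lower number from compound 1 to compound 2 (0.89 log units; beyond the scatter). That modest step exchanged 3,4-dimethoxyphenyl for 2-fluorophenyl at the same place, so it offers only a loose guide. Within the data shown here, no measured pair shows what happens when 2-fluorophenyl gives way to 4-fluorophenyl. Since the incoming group differs from the outgoing one only in how its atoms are joined, a smaller step than that one is expected, probably none beyond the scatter. The expected step is a 1.2-fold higher number from compound 2 to compound 3 (0.07 log units; within the scatter). For compound 3 the estimate is 13000 nM, with an expected range of 5000 nM to 35000 nM.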

Compound 3, half-maximal inhibitory concentration: 3600 nM
Estimate against measurement, compound 3: 3.6-fold (0.56 log units) above; the measured number lies below the stated range.
By their numbers in this assay, from the lowest: compound 3; then compound 2; then compound 1.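

In this assay, the two fluorinated compounds have the same atoms, joined differently, yet the change to 4-fluorophenyl in place of 2-fluorophenyl gives a 3.1-fold lower number from compound 2 to compound 3 (0.49 log units; beyond the scatter), so at this position the place of the fluorine on the phenyl group matters, not just its presence. The exchange of 3,4-dimethoxyphenyl for 4-fluorophenyl on the same carbon with a double bond to nitrogen gives a 24-fold lower number from compound 1 to compound 3 (1.38 log units; beyond the scatter), a wider gap than either other step in the series, and compound 3 is now the strongest of the three, with both of its steps beyond the scatter. No measurement at hand accounts for the difference between the two fluorophenyl compounds.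

The compounds shown leave open where a plain phenyl without fluorine, a chlorophenyl, or a phenyl bearing an amine or a carboxylic acid would fall relative to compound 2 and compound 3. They also leave open whether this order of the three groups would hold on a core changed elsewhere, since all three compounds share one core.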